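Swapping the acyl ring: furan to fluorophenyl

The compounds below may be only part of what the source reports. "The series", "measured", "known", "first", "only" and "open" are said of these compounds alone.

In an assay on cells for inhibition of protein-arginine deiminase type-1 (Homo sapiens), with a stated time of 30 min (a lower number here means a stronger inhibitor, a higher number a weaker inhibitor), the measured compounds gave:
Compound 1 `O=C(N[C@@H](CCn1ccnc1)C(=O)NCc1ccccc1)c1ccco1` reached only a limit, > 10000000 nM.
Compound 2 `Cn1cccc1C(=O)N[C@@H](CCn1ccnn1)C(=O)NCc1ccccc1` gave 112000 nM.
Compound 3 `O=C(N[C@@H](CCn1ccnn1)C(=O)NCc1ccccc1)c1ccco1` gave 1090000 nM.

Compound 3 thus holds the highest of the two numbers given, and the gap to its nearest neighbour is a 9.7-fold higher number from compound 2 to compound 3 (0.99 log units; beyond the scatter). Compound 4 `O=C(N[C@@H](CCn1ccnn1)C(=O)NCc1ccccc1)c1ccc(F)cc1` is not yet measured; it differs from compound 3 by 4-fluorophenyl in place of furan-2-yl on a carbonyl carbon. Within the data shown here, the one measured step at this same carbonyl position, a 9.7-fold higher number from compound 2 to compound 3 (0.99 log units; beyond the scatter), shows that the group there can shift the number modestly, but it gives no direction for a fluorophenyl. The other step, an at least 9.1-fold lower number from compound 1 to compound 3 (0.96 log units; beyond the scatter), concerns a different part of the molecule. A step of uncertain direction, probably near the scatter, is therefore expected. For compound 4 the estimate in this assay is 800000 nM, between 150000 nM and 4000000 nM, an expected step of a 1.4-fold lower number from compound 3 to compound 4 (0.13 log units; within the scatter).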

Compound 4, inhibition constant: > 10000000 nM
Compound 4: a limit, no number (the forecaster's own chance of this, stated with the estimate: 15%); at least 12-fold (1.09 log units) between middle value and limit.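

From the compounds shown here alone, compound 4 reaches only a limit in this assay, so the true size of both steps remains unknown. At this carbonyl position, 4-fluorophenyl gives a weaker inhibitor than either five-membered ring: an at least 9.1-fold higher number from compound 3 to compound 4 (0.96 log units; beyond the scatter), and an at least 89-fold higher number from compound 2 to compound 4 (1.95 log units; beyond the scatter). Replacing the acyl ring can therefore cost as much as replacing the imidazole with the triazole did, and the series now meets the same limit at two different places: the limit of > 10000000 nM in this assay, at which 2 of the 4 values shown sit.

Going by these compounds, whether the fluorine or the six-membered ring matters more remains open, as plain phenyl does not appear here. Also open, on these data alone, is how a thiophen-2-yl group would compare at this carbonyl.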